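The source may report more compounds than this note shows. Statements on the series, on what has been measured and on what is new or still open speak of the compounds shown alone.

Measured in a functional assay on WI-38 cells (Homo sapiens) for inhibition; on this read-out higher numbers stand for weaker inhibition and lower numbers for stronger inhibition:
- compound 1 `CC(C)C(NC(=O)NO)C(=O)NC1CCCCC1`: 58800 nM
- compound 2 `CCC(C)C(NC(=O)NO)C(=O)NC(c1ccccc1)c1ccccc1`: 95800 nM
- compound 3 `CCC(C)C(NC(=O)n1nnc2ccccc21)C(=O)NC(c1ccccc1)c1ccccc1`: 62700 nM

Compound 3, at 62700 nM, lies within the scatter of both other compounds, so the three values give no order among them.

The next compound is compound 4 `CCC(C)C(NC(=O)n1nnc2ccccc21)C(=O)NCc1ccccc1`. It differs from compound 3 by hydrogen in place of phenyl on a saturated chain carbon bound to an amide-type nitrogen and an aromatic carbon.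

Within the data shown here, no measured step covers this change directly. The only one, a 1.5-fold lower number from compound 2 to compound 3 (0.18 log units; within the scatter), concerns a group on a carbonyl carbon, a different place, and it stays within the scatter. It shows only that this series has not yet moved beyond the scatter in a single-place change. Compound 3 differs from compound 1 in more than one place, so that pair gives no clean comparison, but the two values are within the scatter of each other, with compound 1 at 58800 nM. With so little evidence, no direction can be argued, and no change beyond the scatter is expected, though the uncertainty is wide.

The expected size of the change is a 1.0-fold higher number from compound 3 to compound 4 (0.02 log units; within the scatter). For compound 4 the estimated value is 65000 nM, with an expected range from 25000 nM to 170000 nM.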

Compound 4, half-maximal inhibitory concentration: > 100000 nM
Compound 4 ended at the assay's limit (the forecaster's own chance of this, stated with the estimate: 15%); middle value at least 1.5-fold (0.18 log units) away from the limit.
By their numbers in this assay, from the lowest: compounds 1, 3 and 2 (each within the scatter of the next). At a limit, above all of these: compound 4.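

In this assay compound 4 gives > 100000 nM, which is a limit of the assay and not a number. Hydrogen in place of phenyl on a saturated chain carbon bound to an amide-type nitrogen and an aromatic carbon is the only change shown at this place, and it reads an at least 1.5-fold higher number from compound 3 to compound 4 (0.20 log units; that floor lies within the scatter), so the floor of this step does not establish a change beyond the scatter, while its true size stays unknown and may be larger. What this step can show about the place is therefore bounded by the ceiling of the read-out: the limit of > 100000 nM in this assay, at which 1 of the 4 values shown sits.

Going by these compounds, the step cannot say how much of the second phenyl is needed, and whether a methyl group or a longer chain on that saturated carbon would return a value inside the range of this assay stays open. Also open, on these data alone, is whether the same loss of phenyl would read alike in a compound that carries the group of compound 2 on the carbonyl carbon.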